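A few compounds are considered here, and "the series" means these few. Any claim that something is new, unique, unknown or untested is made for them only; others in the source may bear on it.

Among the compounds with values here, compound 1 `COc1ccc(N/C=C\C(=O)c2nc(-c3ccc(OC)cc3)n3ccccc23)cc1` and compound 2 `O=C(/C=C\Nc1cnc2ccccc2c1)c1nc(-c2ccc(C(F)(F)F)cc2)n2ccccc12` share one core and differ from each other in two places, so no single step joins them. In a functional assay on A549 cells (Homo sapiens) for cytotoxicity, read by MTT assay, with a stated time of 48 h (on this read-out higher numbers stand for weaker inhibition and lower numbers for stronger inhibition), compound 1 gives "not determined" (no result reported). Compound 2 reaches only a limit of this assay, recorded as > 30000 nM. Compound 2 thus stands at the edge marked by the limit of > 30000 nM in this assay, at which 1 of the 2 values shown sits, with no number of its own on the scale. Compound 3 `COc1ccc(N/C=C\C(=O)c2nc(-c3ccc(C(F)(F)F)cc3)n3ccccc23)cc1` differs from compound 2 by 4-methoxyphenyl in place of quinolin-3-yl on an amine nitrogen. Within the data shown here, no measured step covers this change, and compound 1, which carries the same 4-methoxyphenyl on the amine nitrogen, offers no number for comparison. The account therefore expects no shift beyond the usual scatter, the estimated step from compound 2 to compound 3 being a number no higher from compound 2 to compound 3 (the limit leaves the size open) in this assay. Compound 3 is expected to give about 30000 nM in this assay, within a range from 8000 nM to 100000 nM, and quite possibly again only a limit.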

Compound 3, half-maximal inhibitory concentration: 21800 nM
Compound 3: middle estimate off by 1.4-fold (0.14 log units), on the high side, within the range that was stated.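

In this assay, compound 3 is the first of the compounds shown with a number of its own, 21800 nM, so this amine nitrogen can carry 4-methoxyphenyl and still give a reading on the scale. Putting 4-methoxyphenyl in place of quinolin-3-yl gives an at least 1.3-fold lower number from compound 2 to compound 3 (0.13 log units; that floor lies within the scatter). That step has only a floor, not a size, and the floor alone does not establish a real change, since compound 2 remains at a limit of the assay: the limit of > 30000 nM in this assay, at which 1 of the 3 values shown sits.

Within the data shown here, compound 1 offers no number, so no step to it can be read, and the effect of the group on the other aryl ring stays open. Also open, from the compounds shown here alone, is how a plain phenyl, a pyridin-3-yl or a phenyl ring bearing a carboxylic acid would read on this amine nitrogen.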